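A few compounds are considered here, and "the series" means these few. Any claim that something is new, unique, unknown or untested is made for them only; others in the source may bear on it.

Compound 1 `COc1ccc(-n2nc(-c3ccc4ccccc4c3)nc2N2C(=O)COC23C=CC(=O)C=C3)cc1`: 200 nM
Compound 2 `CC1OC2(C=CC(=O)C=C2)N(c2nc(-c3cccc4ccccc34)nn2-c2ccccc2)C1=O`: 110 nM
Compound 3 `Cc1ccc(-n2nc(-c3cccc4ccccc34)nc2N2C(=O)COC23C=CC(=O)C=C3)cc1`: 140 nM

These three compounds share one core and have each been tested in a functional assay on HeLa cells (Homo sapiens) for antiproliferative activity, with a stated time of 5 days; a higher number here means a weaker inhibitor, a lower number a stronger inhibitor. Compound 1 has the highest of the three numbers, but the gap to compound 3 and the gap to compound 2 both lie within the usual scatter of this assay, so the three cannot be told apart on these numbers alone. No two of them differ in only one place, so no single structural step can be read off from the measured set.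

Compound 4 `O=C1C=CC2(C=C1)OCC(=O)N2c1nc(-c2ccc3ccccc3c2)nn1-c1ccccc1` is compound 1 with one change: hydrogen in place of methoxy on an aromatic carbon. The methoxy leaves and a hydrogen enters, on an aromatic carbon of a six-membered aromatic ring of carbon only, para to a large group; seen one bond further out, a 4-methoxyphenyl becomes a phenyl.

Among the measured compounds shown here, none of the measured compounds isolates this change. Compound 2 carries an unsubstituted phenyl at the same kind of position, yet it also differs from compound 1 elsewhere, so its value can only hint that an unsubstituted phenyl is tolerated. The step from compound 1 to compound 4 is therefore expected to be small, a 1.3-fold lower number from compound 1 to compound 4 (0.10 log units; within the scatter), and not beyond the scatter. Compound 4 is estimated at 160 nM, with a range from 70 nM to 380 nM.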

Compound 4, half-maximal inhibitory concentration: 120 nM
Beside the measured number, compound 4's estimate is 1.3-fold (0.12 log units) above it, and the stated range covers the measured number.
By their numbers in this assay, from the lowest: compounds 2, 4, 3 and 1 (each within the scatter of the next).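

Among the compounds shown here, this is the first pair in the set that differs in one place only, so the methoxy on the aromatic carbon, para to a large group, can now be judged by itself: in this assay the swap of 4-methoxyphenyl to phenyl reads as a 1.7-fold lower number from compound 1 to compound 4 (0.22 log units; within the scatter) and no more. The methoxy, with its two heavy atoms and one hydrogen-bond acceptor, can therefore go without a difference that repeated measurements could resolve, and what compound 2 could only hint at now rests on a direct comparison on one shared core. Nothing in the data offers an explanation for this result.

Among the compounds shown, only hydrogen and methoxy can be compared directly at this place, so it remains open whether an amine, a carboxylic acid or a longer alkoxy chain there would be tolerated equally well. From the compounds shown here alone, it also remains open whether the same swap would read the same way alongside the different aromatic group carried by compound 2 and compound 3.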